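From difluorophenyl to dihydroxyphenyl on a shared chain

A few compounds are considered here, and "the series" means these few. Any claim that something is new, unique, unknown or untested is made for them only; others in the source may bear on it.

Measured compounds, tested in a functional assay on A549 cells (Homo sapiens) for cytotoxicity; on this read-out lower numbers stand for stronger inhibition and higher numbers for weaker inhibition:
Compound 1 `C=C/C=C\[C@H](C)[C@H](OC(N)=O)[C@@H](C)[C@H](O)[C@@H](C)C/C(C)=C\[C@H](C)[C@@H](O)[C@@H](C)/C=C\CCc1ccc(Oc2ccccc2)cc1`: 10000 nM
Compound 2 `C=C/C=C\[C@H](C)[C@H](OC(N)=O)[C@@H](C)[C@H](O)[C@@H](C)C/C(C)=C\[C@H](C)[C@@H](O)[C@@H](C)/C=C\CCc1cc(F)cc(F)c1`: 1000 nM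
Compound 3 `C=C/C=C\[C@H](C)[C@H](OC(N)=O)[C@@H](C)[C@H](O)[C@@H](C)C/C(C)=C\[C@H](C)[C@@H](O)[C@@H](C)/C=C\CCc1cccc(O)c1`: 190 nM

Compound 2, at 1000 nM, holds the middle place among the three numbers. Compound 3 is lower at 190 nM, and compound 1 is higher at 10000 nM.

Compound 4 `C=C/C=C\[C@H](C)[C@H](OC(N)=O)[C@@H](C)[C@H](O)[C@@H](C)C/C(C)=C\[C@H](C)[C@@H](O)[C@@H](C)/C=C\CCc1cc(O)cc(O)c1` has not yet been measured. It differs from compound 2 as follows: 3,5-dihydroxyphenyl in place of 3,5-difluorophenyl on a saturated chain carbon, two bonds along the chain from a double-bonded chain carbon. In words, it has 3,5-dihydroxyphenyl in place of 3,5-difluorophenyl on a saturated chain carbon, two bonds along the chain from a double-bonded chain carbon.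

Among the compounds with values here, one measured step bears directly on this change. It is a 5.3-fold lower number from compound 2 to compound 3 (0.72 log units; beyond the scatter), a modest move beyond the scatter, made by putting 3-hydroxyphenyl in place of the same 3,5-difluorophenyl. Within the data shown here, no measured compound shows what 3,5-dihydroxyphenyl itself does, so this single step is the only guide, and compound 1 adds no step to it.

A step of similar size and the same direction is therefore expected in this assay. The expected step, which is an estimate, is a 4.0-fold lower number from compound 2 to compound 4 (0.60 log units; beyond the scatter). Compound 4 is expected at about 250 nM, within an estimated range of 60 nM to 1000 nM.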

Compound 4, half-maximal inhibitory concentration: 310 nM
Compound 4: middle estimate off by 1.2-fold (0.09 log units), on the low side; measured number inside the range.
By their numbers in this assay, from the lowest: compounds 3 and 4 (each within the scatter of the next); then compound 2; then compound 1.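

In this assay, 3,5-dihydroxyphenyl in place of 3,5-difluorophenyl on the saturated chain carbon gives a clear step (a 3.2-fold lower number from compound 2 to compound 4 (0.51 log units; beyond the scatter)), so the drop seen earlier with 3-hydroxyphenyl also holds for a ring carrying two hydroxy groups. Adding the second hydroxy in place of hydrogen on an aromatic carbon gives a step that lies within the usual scatter (a 1.6-fold higher number from compound 3 to compound 4 (0.21 log units; within the scatter)), so this read-out cannot separate the one-hydroxy ring from the two-hydroxy ring, and at this position the second hydroxy brings no gain that can be told apart. Nothing given here accounts for why either hydroxyphenyl group gives a lower number than 3,5-difluorophenyl.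

The compounds shown leave open whether the hydroxy group itself is what matters, which 3,5-dimethoxyphenyl or 3,5-diaminophenyl on the same chain carbon could test, and whether 3-fluorophenyl would sit nearer to the difluorophenyl or the hydroxyphenyl compounds. They also leave open whether these rings would keep their numbers on a longer chain, and whether the same ordering would hold on cells other than this one line.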